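The source may hold more compounds than are shown below. What is called first, only, known or untested is meant among the compounds shown, and "the series" means these compounds.

In a functional assay on HepG2 cells (Homo sapiens) for cytotoxicity, with a stated time of 72 h (on this read-out lower numbers stand for an effect already at smaller amounts and higher numbers for an effect only at larger amounts of compound), two compounds sharing one core have been measured: compound 1 (`C=C[C@@](C)(/C=C/c1ccc(Nc2ccc(OC(F)(F)F)cc2)cc1)CCC=C(C)C`) and compound 2 (`C=C[C@@](C)(/C=C/c1ccc(Nc2ccc(F)cc2)cc1)CCC=C(C)C`). Compound 1 gives > 52000 nM, which is a limit of the assay and not a number. Compound 2 gives > 52000 nM, which is also a limit and not a number. All the data so far sit at the limit of > 52000 nM in this assay, at which 2 of the 2 values shown sit. Among the measured compounds shown here, the only measured step is a step that the two limits leave unreadable from compound 1 to compound 2, with fluoro in place of trifluoromethoxy on an aromatic carbon, so it offers no size to carry forward. Compound 3 (`C=C[C@@](C)(/C=C/c1ccc(Nc2ccc(C(F)(F)F)cc2)cc1)CCC=C(C)C`) has trifluoromethyl in place of fluoro on an aromatic carbon, para to a large group: trifluoromethyl in place of fluoro on an aromatic carbon. Since the trifluoromethoxy and fluoro compounds share the limit, no readable step is expected in this assay. Compound 3 is estimated at 52000 nM, within an expected range of 25000 nM to 100000 nM. The estimated step is a number no higher from compound 2 to compound 3 (the limit leaves the size open).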

Compound 3, half-maximal effective concentration: > 52000 nM
Compound 3: only a limit was reported; the forecaster's own chance of this, stated with the estimate: 85%; the middle value sits exactly at the limit.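

In this assay compound 3 gives > 52000 nM as a limit and not a number. The steps from compound 1 and compound 2 to compound 3 cannot be read. The compounds shown leave open how far any of the three lies from that limit, and whether their trifluoromethoxy, fluoro and trifluoromethyl groups differ at all on this read-out.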